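The source may report more compounds than this note shows. Statements on the series, on what has been measured and on what is new or still open speak of the compounds shown alone.

Measured in an assay on isolated protein for inhibition of DNA topoisomerase 1 (Homo sapiens), with a stated time of 30 min, tested at 100 uM; on this read-out higher numbers stand for more inhibition at the one concentration tested (going by the name of the read-out) and lower numbers for less inhibition:
compound 1, `Oc1ccc(-c2cc(-c3ccccc3O)cc(-c3cccc(O)c3)n2)cc1`: compound 1 gives 0%
compound 2, `Oc1ccc(-c2cc(-c3ccc(O)cc3)nc(-c3ccc(O)cc3)c2)cc1`: compound 2 gives 3.8%
compound 3, `Oc1ccc(-c2cc(-c3cccc(O)c3)nc(-c3cccc(O)c3)c2)cc1`: compound 3 gives 0%

Compound 3 stands level with compound 1 at the digits reported, the two together the lowest of the three numbers. Compound 2 reads slightly higher than compound 3, but the gap lies within the usual scatter, so no order among the three can be drawn; the series as a whole shows essentially no inhibition in this assay at the concentration tested.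

Compound 4, `Oc1cccc(-c2cc(-c3ccccc3O)cc(-c3cccc(O)c3)n2)c1`, has not yet been measured. It differs from compound 3 in one place: 2-hydroxyphenyl in place of 4-hydroxyphenyl on an aromatic carbon. The leaving and entering groups hold the same atoms joined differently. Compound 1 also carries a 2-hydroxyphenyl group, and in this assay compound 1 gives 0%.

Within the data shown here, no step between measured compounds is on hand, so the expectation rests on the flat readings alone. Because compound 3 gives 0% and compound 1 gives 0%, the expected step is a number 2 percentage points higher from compound 3 to compound 4 (within the scatter), that is none beyond the scatter. For compound 4 the estimated value in this assay is 2%, with a range from 0% to 12%.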

Compound 4, a percentage reported as inhibition, at one concentration (the size of the read-out at that concentration, not a potency): 0%
Beside the measured number, compound 4's estimate is 2 percentage points above it, within the range that was stated.
By their numbers in this assay, from the lowest: compounds 1, 3, 4 and 2 (each within the scatter of the next).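

In this assay, among these compounds, 2-hydroxyphenyl in place of 4-hydroxyphenyl on the aromatic carbon opposite the ring nitrogen gives no change at the digits printed from compound 3 to compound 4 (within the scatter), which is the first direct one-place comparison at this position, and it shows no readable effect of the swap between these two groups. Among the compounds shown here, a second one-place comparison, which exchanges one hydroxyphenyl group for another, gives no change at the digits printed from compound 1 to compound 4 (within the scatter), so the flat readings now hold for two separate swaps among hydroxyphenyl groups on the shared core and not only for the side-by-side values of the earlier compounds. No other information on hand bears on these flat readings.

Since all of these compounds differ only in where their hydroxyl groups sit, the series leaves open whether any group other than hydroxyphenyl at these places, such as an aminophenyl or a carboxyphenyl group, would give a reading beyond the scatter in this assay. It also leaves open whether the hydroxyl groups matter at all, a question that a plain phenyl group at the same carbon would address.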